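Moving the fluorine: from compound 2 to compound 3

The source may report more compounds than this note shows. Statements on the series, on what has been measured and on what is new or still open speak of the compounds shown alone.

The measured compounds:
compound 1, `COc1ccccc1-c1nnc(-c2ccc(C(=O)N/N=C/c3cccc(O)c3O)cc2)o1`, 102000 nM
compound 2, `COc1ccccc1-c1nnc(-c2ccc(C(=O)N/N=C/c3cccc(F)c3)cc2)o1`, 353000 nM

Both were tested in an ADME assay on THP-1 cells (Homo sapiens) for cytotoxicity; a lower number here means a stronger inhibitor, a higher number a weaker inhibitor. Among the compounds with values here, compound 2 stands at the highest of the two numbers; its nearest neighbour is compound 1, and the only measured step, a 3.5-fold higher number from compound 1 to compound 2 (0.54 log units; beyond the scatter), separates them.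

Compound 3, `COc1ccccc1-c1nnc(-c2ccc(C(=O)N/N=C/c3ccccc3F)cc2)o1`, shares the core of compound 2 and differs from it only as follows: 2-fluorophenyl in place of 3-fluorophenyl on a carbon with a double bond to nitrogen.

Within the data shown here, the one measured step bears only loosely on this change. It exchanged a 2,3-dihydroxyphenyl for a 3-fluorophenyl and gave a modest rise, whereas compound 3 keeps a single fluorine on the same ring and merely shifts it. Among the measured compounds shown here, there is no measured pair that moves a fluorine within the ring, so compound 2 is the only anchor. Compound 3 is therefore expected to give a number close to that of compound 2 in this assay, with a 1.0-fold lower number from compound 2 to compound 3 (0.00 log units; within the scatter) meaning no step beyond the scatter. The estimate for compound 3 is 350000 nM, with a range from 150000 nM to 800000 nM.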

Compound 3, half-maximal inhibitory concentration: 313000 nM
Estimate against measurement, compound 3: 1.1-fold (0.05 log units) above, and the stated range covers the measured number.
By their numbers in this assay, from the lowest: compound 1; then compounds 3 and 2 (each within the scatter of the next).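

In this assay the single fluorine can sit in either of the two ring placements tested on the carbon with a double bond to nitrogen: 2-fluorophenyl in place of 3-fluorophenyl gives a 1.1-fold lower number from compound 2 to compound 3 (0.05 log units; within the scatter) and so leaves the read-out within the scatter. The exchange of the 2,3-dihydroxyphenyl now has a second reading, a 3.1-fold higher number from compound 1 to compound 3 (0.49 log units; beyond the scatter), which lies beyond the scatter as does a 3.5-fold higher number from compound 1 to compound 2 (0.54 log units; beyond the scatter), so the separation of compound 1 from the fluorinated compounds holds for both fluorophenyl groups rather than resting on one compound. No measurement on hand gives a reason for these steps.

The compounds shown leave open whether both hydroxyl groups of the 2,3-dihydroxyphenyl are needed for the lower number of compound 1 or whether a phenyl ring carrying one hydroxyl would behave the same way. They also leave open whether the indifference to where the fluorine sits extends to larger or different groups at this ring, such as a chlorine, a trifluoromethyl, an amine or a carboxylic acid.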